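Urea series: cinnamamide linker replaced by biphenyl amide

This account rests on a few compounds, and the source may have more. Where it says the series, first, only, none or still open, it means among the compounds named here.

Compound 1 `O=C(/C=C/c1ccc(NC(=O)Nc2ccc(Cl)c(C(F)(F)F)c2)cc1)NC1CCC1` gives 4430 nM in a functional assay on HT-29 cells (Homo sapiens) for inhibition, read by MTT assay, with a stated time of 120 h (a lower number here means a stronger inhibitor, a higher number a weaker inhibitor), the second highest of the three numbers shown. Compound 2 `CC(NC(=O)/C=C/c1ccc(NC(=O)Nc2ccc(Cl)c(C(F)(F)F)c2)cc1)c1ccccc1` gives 1060 nM, and a 4.2-fold lower number from compound 1 to compound 2 (0.62 log units; beyond the scatter). Compound 3 `CC(NC(=O)c1ccc(-c2ccc(NC(=O)Nc3cc(C(F)(F)F)ccc3Cl)cc2)cc1)c1ccccc1` gives 6570 nM, which sits within the scatter of compound 1. The unmeasured compound 4 `CNC(=O)c1cccc(-c2ccc(NC(=O)Nc3ccc(Cl)c(C(F)(F)F)c3)cc2)c1` differs from compound 1 by 3-(methylcarbamoyl)phenyl in place of 2-(cyclobutylcarbamoyl)ethenyl on an aromatic carbon. Within the data shown here, no measured step covers this change; the one step, from compound 1 to compound 2, alters the amide substituent and not the linker, so it bears only loosely. Compound 3, with a biphenyl amide linker, shows a number close to that of compound 1. Compound 4 is therefore expected to remain weak, with a 1.4-fold higher number from compound 1 to compound 4 (0.13 log units; within the scatter) estimated as not beyond the scatter. The estimate for compound 4 is 6000 nM, range 2000 nM to 20000 nM.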

Compound 4, half-maximal inhibitory concentration: 29300 nM
Estimate against measurement, compound 4: 4.9-fold (0.69 log units) below; measured number outside the range, above it.
By their numbers in this assay, from the lowest: compound 2; then compounds 1 and 3 (each within the scatter of the next); then compound 4.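

On this aromatic carbon the group is not freely exchangeable: in this assay, 3-(methylcarbamoyl)phenyl in place of 2-(cyclobutylcarbamoyl)ethenyl gives a 6.6-fold higher number from compound 1 to compound 4 (0.82 log units; beyond the scatter) and leaves a weaker compound. The earlier step changed only the amide substituent, whereas this one shows that replacing the whole group at this position also moves the number beyond the scatter. No available data explain the loss.

Still open, as far as these compounds go, is whether the loss follows from the added phenyl ring or from the methyl on the amide nitrogen. Also open, from the compounds shown here alone, is how a carboxylic acid or an amine in place of the methylcarbamoyl group would read.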